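Amino for chloro on two related cores: estimating compound 4

The compounds below may be only part of what the source reports. "The series", "measured", "known", "first", "only" and "open" are said of these compounds alone.

Compound 1, `ClCc1ccccc1Cn1cnc2c(Cl)nc(Cl)nc21`, gives 1200 nM in a functional assay on HCT-15 cells (Homo sapiens) for cytotoxicity, read by sulforhodamine B assay, with a stated time of 48 h; a higher number here means a weaker inhibitor of growth, a lower number a stronger inhibitor of growth.
Compound 2, `ClCc1cccc(Cn2cnc3c(Cl)nc(Cl)nc32)c1`, gives 6910 nM in this assay.
Compound 3, `Nc1nc(Cl)c2ncn(Cc3ccccc3CCl)c2n1`, gives 7410 nM in this assay.

Compound 1 and compound 2 have the same atoms joined differently; the difference between the two cores is not broken down here. Compound 1 is the lowest of the three numbers, and compound 2 and compound 3 sit close to one another, within the scatter of repeated measurement.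

Compound 3 differs from compound 1 by one change, (amino in place of chloro on an aromatic carbon), and this change made a 6.2-fold higher number from compound 1 to compound 3 (0.79 log units; beyond the scatter) in this assay. Compound 4, `Nc1nc(Cl)c2ncn(Cc3cccc(CCl)c3)c2n1`, has not yet been measured. Within the data shown here, it differs from compound 2 by amino in place of chloro on an aromatic carbon, which is the same change, at a place described in the same words, as the one from compound 1 to compound 3.

Among the measured compounds shown here, only one measured example of this change exists, so the expected size for compound 4 rests on that single step. Compound 4 is therefore expected to give 35000 nM in this assay, a step of a 5.1-fold higher number from compound 2 to compound 4 (0.70 log units; beyond the scatter), because compound 2 stands at 6910 nM and the matching change was a 6.2-fold higher number from compound 1 to compound 3 (0.79 log units; beyond the scatter). For the measured compounds named here, the estimate for compound 4 is expected to lie between 12000 nM and 100000 nM, allowing for the single precedent and the usual scatter.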

Compound 4, concentration for total growth inhibition: 6760 nM
Estimate against measurement, compound 4: 5.2-fold (0.71 log units) above; the measured number lies below the stated range.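

In this assay, amino in place of chloro on the core of compound 2 gives a 1.0-fold lower number from compound 2 to compound 4 (0.01 log units; within the scatter), so on this core the change leaves no difference beyond the scatter. Set beside the earlier step, the same change does not carry over in size from one core to the other, even though the two cores have the same atoms joined differently: the same change on two cores in this assay, a 6.2-fold higher number (0.79 log units; beyond the scatter) from compound 1 to compound 3 and a 1.0-fold lower number (0.01 log units; within the scatter) from compound 2 to compound 4, 6.3-fold (0.80 log units) apart, beyond the scatter of two such steps

Among these compounds, this shows that, in this series, the step measured on one core cannot be taken as a guide to its size on the other, but it rests on only two pairs and does not show what in the cores sets the steps apart, nor how the change would behave on any further core.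

The compounds shown leave open whether a methylamino or a hydroxyl group, placed on that same aromatic carbon between two ring nitrogen atoms, would also give steps that part ways between these two cores. They also leave open whether the gap between the two steps would hold in a read-out on other cells.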